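A five-membered ring in place of a six-membered one

A few compounds are considered here, and "the series" means these few. Any claim that something is new, unique, unknown or untested is made for them only; others in the source may bear on it.

In an in vitro ADME assay on microsomes from liver (Homo sapiens) for metabolic stability, with a stated time of 15 min (on this read-out higher numbers stand for fast clearance and lower numbers for slow clearance), compound 3 `CCc1nn2c(-c3c(C)cc(C)cc3OC)cccc2c1N(CC1CCOCC1)CC1CC1` gives 450 mL.min-1.g-1. Compound 1 `CCc1nn2c(-c3c(C)cc(OC)cc3OC)cccc2c1N(CC1CCOCC1)CC1CC1` gives the same number, 450 mL.min-1.g-1, while compound 2 `CCc1nn2c(-c3c(C)cc(C)cc3OC)cccc2c1N(CC1CC1)CC1CCCO1` gives 1230 mL.min-1.g-1. Going by the values given here, compound 3 therefore shares the lowest number measured so far with compound 1.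

Compound 4 `CCc1nn2c(-c3c(C)cc(C)cc3OC)cccc2c1N(CC1CC1)CC1CCOC1` has not been measured. It carries oxolan-3-yl in place of oxan-4-yl on a saturated chain carbon bound to a nitrogen on an aromatic ring.

The closest guide is a 2.7-fold lower number from compound 2 to compound 3 (0.44 log units; beyond the scatter), a modest step that comes with oxan-4-yl in place of oxolan-2-yl at that same place. Compound 4 has the oxolane ring of compound 2, but attached through a different ring position, so the data cannot show whether it will behave the same way. The other measured step, no change at the digits printed from compound 1 to compound 3 (within the scatter), concerns methyl in place of methoxy on an aromatic carbon and says little about this change.

The expected outcome is a 1.8-fold higher number from compound 3 to compound 4 (0.25 log units; within the scatter), a partial return towards faster clearance. For compound 4, the estimated value is 800 mL.min-1.g-1, with an expected range of 380 mL.min-1.g-1 to 1500 mL.min-1.g-1.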

Compound 4, intrinsic clearance in microsomes: 1350 mL.min-1.g-1
Estimate against measurement, compound 4: 1.7-fold (0.23 log units) below; measured number inside the range.
By their numbers in this assay, from the lowest: compounds 1 and 3 (each within the scatter of the next); then compounds 2 and 4 (each within the scatter of the next).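

In this assay, oxolan-3-yl in place of oxan-4-yl on this saturated chain carbon gives a 3.0-fold higher number from compound 3 to compound 4 (0.48 log units; beyond the scatter) and so shows that the lower number of compound 3 does not carry over to this five-membered ring. Moving the ring attachment, with oxolan-3-yl in place of oxolan-2-yl, gives a 1.1-fold higher number from compound 2 to compound 4 (0.04 log units; within the scatter) and so, among these compounds, the two oxolane attachments cannot be told apart, while both stand apart from oxan-4-yl. Nothing in the data shown accounts for this difference between the rings.

As far as these compounds go, it remains open whether the lower number belongs to the six-membered ring in general or to oxan-4-yl alone, which oxan-3-yl or a piperidin-4-yl ring at this place could test. An open 2-methoxyethyl chain could likewise show whether a ring is needed here at all.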